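Chloro for methyl on the benzamide of compound 1

The source may hold more compounds than are shown below. What is called first, only, known or untested is meant among the compounds shown, and "the series" means these compounds.

Working notes on the series. The common read-out is an assay on cells for inhibition of cytochrome P450 11B2, mitochondrial (Homo sapiens), read by HTRF; on this read-out lower numbers stand for stronger inhibition and higher numbers for weaker inhibition. Compound 1, `Cc1ccc(C(=O)Nc2cccnc2)cc1`, is a small benzamide; in this assay compound 1 gives > 3000 nM, and this is a limit of the assay, not a measured number, so compound 1 sits at the limit of > 3000 nM in this assay, at which 1 of the 3 values shown sits, and is the only one of the three measured compounds that does. The two elaborated compounds differ from it in much of their structure and show measured values: compound 2, `CCS(=O)(=O)N1CC2(CN(c3cncc(N4C(=O)c5ccc(Cl)cc5C4(C)C)c3)C2)C1`, gives 16 nM in this assay, and compound 3, `CC(=O)N1CCC(c2cncc(N3C(=O)c4ccc(Cl)cc4C3(C)C)c2)CC1`, gives 5 nM in this assay. The values of compound 2 and compound 3 lie within the usual scatter of each other. For the measured compounds named here, no pair of measured compounds differs in a single place, so no single-point step is available from the measurements themselves.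

Going by the values given here, compound 4, `O=C(Nc1cccnc1)c1ccc(Cl)cc1`, is the one new compound to be measured. It differs from compound 1 by chloro in place of methyl on an aromatic carbon. The change is a small one on the aromatic carbon, para to a group of 9 heavy atoms, and leaves the rest of compound 1 untouched.

With compound 1 known only as a limit, the step from compound 1 to compound 4 cannot be anchored on a number; the expectation is that the step that the limit leaves unreadable from compound 1 to compound 4 stays within the scatter, with no change beyond it. Compound 4 is therefore estimated at 5000 nM, between 1500 nM and 20000 nM, with a good chance that the assay again reports only a limit.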

Compound 4, half-maximal inhibitory concentration: 420 nM
For compound 4 the middle estimate is 12-fold (1.08 log units) above the measured one; the measured number lies below the stated range.
By their numbers in this assay, from the lowest: compound 3; then compound 2; then compound 4. At a limit, above all of these: compound 1.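

Chloro in place of methyl on an aromatic carbon, para to a group of 9 heavy atoms, gives in this assay an at least 7.1-fold lower number from compound 1 to compound 4 (0.85 log units; beyond the scatter), the first single-place step in the series, so a change of one heavy atom at this position is enough to bring the small benzamide from a limit onto a measured number. Compound 1 gives > 3000 nM, which is a limit of the assay and not a number. The size of the step therefore has a bound on one side only, and how much lower the number for compound 4 lies than the true value for compound 1 cannot be told: the limit of > 3000 nM in this assay, at which 1 of the 4 values shown sits.

Whether this shift is particular to chloro stays open, since the compounds shown include no fluoro, bromo, methoxy or nitrile on the same aromatic carbon, and none with the group at another place on the ring. No single-place step links compound 4 to compound 2 or compound 3, so the compounds shown do not tell how this position reads on those larger structures.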